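Urea Cytotoxicity Series: Chloro to Trifluoromethyl on a Nitrophenyl

A few compounds are considered here, and "the series" means these few. Any claim that something is new, unique, unknown or untested is made for them only; others in the source may bear on it.

Compound 1 `O=C(NCCCCC(c1ccc(F)cc1)c1ccc(F)cc1)Nc1ccc(Cl)cc1` gives 7680 nM in a functional assay on MDA-MB-231 cells (Homo sapiens) for cytotoxicity, read by MTT assay, with a stated time of 48 h; a higher number here means a weaker inhibitor, a lower number a stronger inhibitor; compound 2 `O=C(NCCCCC(c1ccc(F)cc1)c1ccc(F)cc1)Nc1ccc(C(F)(F)F)cc1` gives 2780 nM; compound 3 `O=C(NCCCCC(c1ccc(F)cc1)c1ccc(F)cc1)Nc1ccc([N+](=O)[O-])c(Cl)c1` gives 3470 nM.

All three share one core and differ only in the aryl group on the urea nitrogen. The difference between the cores of compound 1 and compound 3 is 3-chloro-4-nitrophenyl in place of 4-chlorophenyl on an amide-type nitrogen, and it gave a 2.2-fold lower number from compound 1 to compound 3 (0.35 log units; beyond the scatter). Compound 2 and compound 3 differ by a 1.2-fold higher number from compound 2 to compound 3 (0.10 log units; within the scatter). The change trifluoromethyl in place of chloro on an aromatic carbon gave a 2.8-fold lower number from compound 1 to compound 2 (0.44 log units; beyond the scatter).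

Compound 4 `O=C(NCCCCC(c1ccc(F)cc1)c1ccc(F)cc1)Nc1ccc([N+](=O)[O-])c(C(F)(F)F)c1` has not yet been measured in this assay. It differs from compound 3 by trifluoromethyl in place of chloro on an aromatic carbon. This is the same kind of change as that from compound 1 to compound 2, but not the same: in compound 2 the trifluoromethyl sits para to a large group, whereas in compound 4 it sits ortho to a nitro group and meta to a large group. Resting on the one earlier step, a 2.8-fold lower number from compound 1 to compound 2 (0.44 log units; beyond the scatter), compound 4 is expected to show a 1.7-fold lower number from compound 3 to compound 4 (0.24 log units; within the scatter), probably a smaller shift since the surroundings differ. The estimate for compound 4 is 2000 nM, expected to fall between 900 nM and 4500 nM.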

Compound 4, half-maximal inhibitory concentration: 4550 nM
For compound 4 the middle estimate is 2.3-fold (0.36 log units) below the measured one, outside the stated range (above it).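

In this assay, trifluoromethyl in place of chloro on an aromatic carbon ortho to a nitro group gave a 1.3-fold higher number from compound 3 to compound 4 (0.12 log units; within the scatter), so on this core the change has no readable effect. Set beside the earlier case, the same change does not carry over unaltered from one core to the other: the same change on two cores in this assay, a 2.8-fold lower number (0.44 log units; beyond the scatter) from compound 1 to compound 2 and a 1.3-fold higher number (0.12 log units; within the scatter) from compound 3 to compound 4, 3.6-fold (0.56 log units) apart, beyond the scatter of two such steps. This rests on a single pair per core, and it does not show what separates them, as the two pairs differ both in the nitro group and in the place of the exchanged group, and they cannot tell these apart.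

The compounds shown leave open whether the lower number seen with trifluoromethyl on the core of compound 1 would return on a core carrying a nitrile or a methoxy group in place of the nitro group. They also leave open whether the step would read the same with a longer chain between the urea and the two fluorophenyl rings.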